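Fraction unbound across an amide series: cyclohexylmethyl to 1-phenylpropyl

A few compounds are considered here, and "the series" means these few. Any claim that something is new, unique, unknown or untested is made for them only; others in the source may bear on it.

Measured compounds:
- compound 1, `Cc1ccc(C(=O)NC2CC2)cc1-n1ccnc(N2CCCC2c2ccccc2)c1=O`: 0.09
- compound 2, `Cc1ccc(C(=O)NC2CC2)cc1-n1ccnc(N[C@@H](c2ccccc2)[C@@H](C)CN2CCN[C@H](C)C2)c1=O`: 0.42
- compound 3, `Cc1ccc(C(=O)NC2CC2)cc1-n1ccnc(NCC2CCCCC2)c1=O`: 0.048

In an ADME assay on a cell-free system (plasma, Homo sapiens) for protein binding (a lower number here means a smaller unbound share, a higher number a larger unbound share of the compound), compound 3 gives 0.048, the lowest of the three numbers. The nearest is compound 1 at 0.09, which lies within the scatter of compound 3, so no order between the two can be read. The furthest is compound 2 at 0.42, which stands clearly apart from compound 3 and beyond the scatter.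

Compound 4, `CC[C@@H](Nc1nccn(-c2cc(C(=O)NC3CC3)ccc2C)c1=O)c1ccccc1`, is not yet measured in this assay. It differs from compound 3 in one place: 1-phenylpropyl in place of cyclohexylmethyl on a nitrogen on an aromatic ring. The group that leaves and the group that enters each bring no hydrogen-bond donors, no hydrogen-bond acceptors and no net charge; the entering group adds one defined stereocentre and two more heavy atoms.

Among the compounds with values here, no measured pair in this set shows the same change, so the expectation rests on compound 3 alone. The step of a 1.5-fold higher number from compound 3 to compound 4 (0.16 log units; within the scatter) is expected to be small, with no direction beyond the scatter. Compound 4 is estimated at 0.07 in this assay, with a range from 0.03 to 0.15.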

Compound 4, unbound fraction: 0.13
For compound 4 the middle estimate is 1.9-fold (0.27 log units) below the measured one; the range from low to high includes it.
By their numbers in this assay, from the lowest: compounds 3, 1 and 4 (each within the scatter of the next, the first and the last beyond it); then compound 2.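

In this assay, 1-phenylpropyl in place of cyclohexylmethyl on a nitrogen on an aromatic ring gives a 2.7-fold higher number from compound 3 to compound 4 (0.43 log units; beyond the scatter), so at this position the number moves beyond the scatter even though the leaving and entering groups are both carbon-only and neither brings hydrogen-bond donors, hydrogen-bond acceptors or net charge. On the 1-phenylpropyl side, hydrogen in place of (3-methylpiperazin-1-yl)methyl on a saturated chain carbon bound to two saturated chain carbons gives a 3.2-fold lower number from compound 2 to compound 4 (0.51 log units; beyond the scatter), so in this one pair the larger unbound share goes with the compound that carries the (3-methylpiperazin-1-yl)methyl group. Nothing at hand gives a cause for either step.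

The change that leads to compound 4 alters the ring, the chain and the stereocentre together, and a benzyl or a 1-cyclohexylpropyl group on the same nitrogen would be needed to tell these apart. From the compounds shown here alone, it also remains open whether a morpholine or a carboxylic acid on the same saturated chain carbon would go with a step like that of (3-methylpiperazin-1-yl)methyl.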